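The compounds below may be only part of what the source reports. "The series", "measured", "known", "first", "only" and "open" are said of these compounds alone.

Of the compounds shown here, three built on one shared core have been measured so far. Compound 1 `NC(=O)N(O)CC1=Cc2cc(OCc3ccc(C(F)(F)F)cc3)ccc2OC1` gives 490 nM in an assay (Cavia porcellus) for inhibition of Polyunsaturated fatty acid 5-lipoxygenase (Homo sapiens) (a lower number here means a stronger inhibitor, a higher number a weaker inhibitor), compound 2 `CCCCCCOc1ccc2c(c1)C=C(CN(O)C(N)=O)CO2` gives 340 nM in this assay, and compound 3 `NC(=S)N(O)CC1=Cc2cc(Oc3ccccc3)ccc2OC1` gives 200 nM in this assay. Compound 2 stands second highest of the three numbers; its nearest neighbour is compound 1 and its furthest is compound 3, and both gaps lie within the scatter, so no order among the three can be claimed. Compound 4 `NC(=O)N(O)CC1=Cc2cc(-c3ccccc3)ccc2OC1` differs from compound 2 in one place: phenyl in place of hexyloxy on an aromatic carbon. Among the compounds with values here, no measured pair shows this change, so the direction rests on expectation alone. In this assay the change is expected to give a 1.8-fold higher number from compound 2 to compound 4 (0.25 log units; within the scatter), a modest move toward a higher number. Compound 4 is therefore estimated at 600 nM in this assay, within a range from 200 nM to 2000 nM.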

Compound 4, half-maximal inhibitory concentration: 230 nM
Compound 4: middle estimate off by 2.6-fold (0.42 log units), on the high side; measured number inside the range.
By their numbers in this assay, from the lowest: compounds 3, 4, 2 and 1 (each within the scatter of the next, the first and the last beyond it).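

Phenyl in place of hexyloxy on an aromatic carbon gives a 1.5-fold lower number from compound 2 to compound 4 (0.17 log units; within the scatter) in this assay, so at this position a six-membered aromatic ring and an open chain read alike. Within the data shown here, this is the first pair differing in one place, which the earlier compounds could not provide. Nothing measured here bears on why the two groups read alike. Still open, going by these compounds, is how an amine or a carboxylic acid would read at this position. A chain longer than hexyloxy, or a phenyl carrying a fluorine, is equally untested among the compounds shown.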